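Lengthening the chain of compound 1 by four carbons

The source may hold more compounds than are shown below. What is called first, only, known or untested is meant among the compounds shown, and "the series" means these compounds.

Of the compounds shown here, two have been measured in a functional assay with platelet-activating factor receptor (Cavia porcellus) as the target; on this read-out lower numbers stand for an effect already at smaller amounts and higher numbers for an effect only at larger amounts of compound. Compound 1 `CCCC/C(=C\C=C\C(=O)N[C@H](C)CCCc1cccnc1)c1ccc(OC)cc1` gives 0.68 mg/kg in this assay. Compound 2 `COc1cccc(C(=C/C=C/C(=O)NCCCCc2cccnc2)c2cccc(OC)c2)c1` gives 0.36 mg/kg in this assay. Compound 1 thus has the higher of the two numbers, but its gap to compound 2 lies within the usual scatter, so the two cannot be told apart. Compound 3 `CCCCCCCC/C(=C\C=C\C(=O)N[C@H](C)CCCc1cccnc1)c1ccc(OC)cc1` has not yet been measured. It differs from compound 1 in one place: butyl in place of hydrogen on a saturated chain carbon, four bonds along the chain from a double-bonded chain carbon. Going by the values given here, no pair of measured compounds shows this kind of change, so the data give no step to guide the expectation, and a plain chain extension of this sort is expected to shift the number little, most likely not beyond the scatter. The expected step is a 1.2-fold higher number from compound 1 to compound 3 (0.07 log units; within the scatter). For compound 3 the estimate is 0.8 mg/kg, with a range from 0.3 mg/kg to 2.2 mg/kg.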

Compound 3, dose for 50% inhibition: 0.1 mg/kg
For compound 3 the middle estimate is 8.0-fold (0.90 log units) above the measured one, outside the stated range (below it).
By their numbers in this assay, from the lowest: compound 3; then compounds 2 and 1 (each within the scatter of the next).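

In this assay, the saturated chain of compound 1 proves to be a place where the number responds clearly: butyl in place of hydrogen, four bonds along the chain from a double-bonded chain carbon, gives a 6.8-fold lower number from compound 1 to compound 3 (0.83 log units; beyond the scatter). The change adds carbon only, with no ring, no charge and no hydrogen-bond donors or acceptors, yet it moves the number toward an effect at smaller amounts. No measurement shown here bears on the cause of this fall.

A single step cannot show whether a chain of intermediate length, such as hexyl, already gives much of this gain, or whether a still longer decyl would take the number lower or raise it again. It also leaves open how the number would respond to an amine or a carboxylic acid carried on the chain.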